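The source may report more compounds than this note shows. Statements on the series, on what has been measured and on what is new or still open speak of the compounds shown alone.

Working notes on the series, values from a physicochemical assay for lipophilicity; a lower number here means a more polar compound, a higher number a more lipophilic compound:

- compound 1 `C[C@H]1CC[C@@H]2[C@@H](OC(=O)[C@]23CC(c2ccc(Br)cc2)N(c2ccccc2)O3)[C@]2(C)C(=O)C=C[C@@]12O`: 4
- compound 2 `C[C@H]1CC[C@@H]2[C@@H](OC(=O)[C@]23CC(c2ccc(F)cc2)N(c2ccccc2)O3)[C@]2(C)C(=O)C=C[C@@]12O`: 3.35
- compound 3 `C[C@H]1CC[C@@H]2[C@@H](OC(=O)[C@]23CC(c2ccccc2)N(c2ccccc2)O3)[C@]2(C)C(=O)C=C[C@@]12O`: 3.19

Compound 3 stands at 3.19. It cannot be separated from compound 2, as the step is a number 0.16 log units lower from compound 2 to compound 3 (within the scatter). It is clearly apart from compound 1, with a step of a number 0.81 log units lower from compound 1 to compound 3 (beyond the scatter).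

Next is compound 4 `C[C@H]1CC[C@@H]2[C@@H](OC(=O)[C@]23CC(c2cccc(Cl)c2)N(c2ccccc2)O3)[C@]2(C)C(=O)C=C[C@@]12O`, which differs from compound 3 by chloro in place of hydrogen on an aromatic carbon, meta to a large group.

For the measured compounds named here, two measured steps bear on this change. Both are read in reverse. Each of them removes a halogen. Removing bromo gives a number 0.81 log units lower from compound 1 to compound 3 (beyond the scatter), while removing fluoro gives a number 0.16 log units lower from compound 2 to compound 3 (within the scatter). The step between these two halogens is a number 0.65 log units lower from compound 1 to compound 2 (beyond the scatter). Chloro itself has not been measured, and no measured compound is known to carry a substituent meta to a large group, so the range is kept wide. Chloro falls between fluoro and bromo among the halogens, so a step between those two sizes is expected, closer to the bromo one.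

The expected step is a number 0.61 log units higher from compound 3 to compound 4 (beyond the scatter), an estimated rise in the number beyond the scatter. The estimate for compound 4 is 3.8, with an expected range from 3.5 to 4.1.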

Compound 4, partition coefficient: 3.87
Beside the measured number, compound 4's estimate is 0.07 log units below it; low and high end bracket the measured number.
By their numbers in this assay, from the lowest: compounds 3 and 2 (each within the scatter of the next); then compounds 4 and 1 (each within the scatter of the next).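

In this assay, for the compounds shown here, chloro on an aromatic carbon, meta to a large group, gives a number 0.68 log units higher from compound 3 to compound 4 (beyond the scatter) and so shows that a halogen at this place can carry a step beyond the scatter, which the earlier compounds showed only for 4-bromophenyl and not for 4-fluorophenyl. Set against the other substituted rings, 3-chlorophenyl gives a number 0.52 log units higher from compound 2 to compound 4 (beyond the scatter) as a step beyond the scatter, while a number 0.13 log units lower from compound 1 to compound 4 (within the scatter) stays within it, so 3-chlorophenyl and 4-bromophenyl cannot be told apart here, and the series now has two levels, one holding phenyl and 4-fluorophenyl and the other holding 3-chlorophenyl and 4-bromophenyl. Nothing available accounts for these steps or for the grouping.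

Whether the step follows the ring place or the identity of the halogen stays open, since the compounds shown offer neither 4-chlorophenyl nor 3-bromophenyl to pair with those at hand. Also open is how far this assay would fall with an amine, a hydroxyl or a carboxylic acid on this ring, since every substituent shown here is a halogen.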